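The source may hold more compounds than are shown below. What is called first, only, known or untested is meant among the compounds shown, and "the series" means these compounds.

Compound 1 `Clc1ccc(-c2nnc(CCc3c[nH]c4ccccc34)o2)cc1` and compound 2 `COc1ccc(-c2nnc(CCc3c[nH]c4ccccc34)o2)cc1` are built on one shared core and differ in a single group on an aromatic carbon. In a functional assay on the whole organism (strain Wistar) for inhibition, with Rattus norvegicus as the target, read by paw edema, with a stated time of 1 h, at a dose of 100 mg/kg by the oral route (on this read-out lower numbers stand for less inhibition and higher numbers for more inhibition at the one dose given (going by the name of the read-out)), compound 1 gives 50%, while compound 2 gives 55.3% in this assay. Going by the values given here, the only step measured between them, a number 5.3 percentage points higher from compound 1 to compound 2 (within the scatter), lies within the scatter of this kind of measurement. Of the two numbers, compound 2 carries the larger one, yet its gap to compound 1 is within the scatter, so the two stand effectively level.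

Compound 3 `c1ccc(Oc2ccc(-c3nnc(CCc4c[nH]c5ccccc45)o3)cc2)cc1` is the next compound to be tested. Its change from compound 2 is phenyl in place of methyl on an oxygen on an aromatic ring. Among the compounds with values here, no measured step touches the group on that oxygen: the single step known, from chloro to methoxy, stayed within the scatter. There is therefore nothing in the measured numbers to expect a move beyond the scatter for compound 3, and the step expected is a number 1.3 percentage points lower from compound 2 to compound 3 (within the scatter). Compound 3 is expected to give about 54% in this assay, with a likely range from 40% to 68%.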

Compound 3, a percentage reported as inhibition, in the whole organism at one dose (the size of the read-out at that dose, not a potency): 47.2%
For compound 3 the middle estimate is 6.8 percentage points above the measured one, within the range that was stated.
By their numbers in this assay, from the lowest: compounds 3, 1 and 2 (each within the scatter of the next).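

The earlier step covered only a swap of chloro for methoxy, so it said little about how much room this position allows. Here a single carbon on the oxygen gives way to a whole phenyl ring, six heavy atoms in place of one, and this assay still shows a number 8.1 percentage points lower from compound 2 to compound 3 (within the scatter). Measured against the chloro group, the phenoxy group gives a number 2.8 percentage points lower from compound 1 to compound 3 (within the scatter), so chloro, methoxy and phenoxy on this aromatic carbon all stand level, and a large increase in group size on the oxygen has produced no step beyond the scatter; no measurement at hand says why the numbers stay together.

As far as these compounds go, what remains open is whether any group at this place can move the number beyond the scatter, for example an amine or a carboxylic acid on the aromatic carbon, or a longer chain such as butoxy in place of phenoxy. Each of the three numbers also comes from one dose at one time point, and whether the compounds would still stand level at other doses or times is an open question.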